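Expected Cytotoxicity of Compound 4 from Three Measured Analogues

The source may report more compounds than this note shows. Statements on the series, on what has been measured and on what is new or still open speak of the compounds shown alone.

Compound 1 `COc1ccc(-c2cc3ccc(OCCCn4cc(CNC(=O)CCCCC5CCSS5)nn4)cc3oc2=O)cc1`: 62%
Compound 2 `Cc1cc(=O)oc2cc(OCCCCCn3cc(CNC(=O)CCCCC4CCSS4)nn3)ccc12`: 70.3%
Compound 3 `CCOC(=O)c1cc2ccc(OCCCCCn3cc(CNC(=O)CCCCC4CCSS4)nn3)cc2oc1=O`: 39.5%

In a functional assay on PC-12 cells (Rattus norvegicus) for cytotoxicity, read by MTT assay, with stated times of 3 h and 2 h, tested at 20 uM (a higher number here means a stronger effect of the compound at the concentration tested, a lower number a weaker effect), compound 3 gives 39.5%, the lowest of the three numbers; compound 1 stands higher by a gap beyond the scatter, and compound 2 higher still, also beyond the scatter. Compound 4 `COc1ccc(-c2cc3ccc(OCCCCCn4cc(CNC(=O)CCCCC5CCSS5)nn4)cc3oc2=O)cc1OC` differs from compound 3 in one place: 3,4-dimethoxyphenyl in place of ethoxycarbonyl on an aromatic carbon. Within the data shown here, no step between two measured compounds differing in a single place is available, so the effect of this change is not isolated by the data; still, the structure of compound 1 resembles that of compound 4 more closely than the structure of compound 3 does, and compound 1 gives 62%. Compound 4 is therefore expected to rise, with a step of a number 20.5 percentage points higher from compound 3 to compound 4 (beyond the scatter) beyond the scatter. The estimate for compound 4 is 60%, within 45% to 75%.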

Compound 4, a percentage reported as activity, at one concentration (the size of the read-out at that concentration, not a potency): 51.9%
Beside the measured number, compound 4's estimate is 8.1 percentage points above it; measured number inside the range.
By their numbers in this assay, from the lowest: compound 3; then compound 4; then compounds 1 and 2 (each within the scatter of the next).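

In this assay, among these compounds, 3,4-dimethoxyphenyl in place of ethoxycarbonyl on this aromatic carbon, two atoms from the ring oxygen, gives a number 12.4 percentage points higher from compound 3 to compound 4 (beyond the scatter), the first step that isolates this position. The reading at this position therefore responds to the group it carries. The two groups have equal counts of hydrogen-bond donors and acceptors, so this step comes with more heavy atoms and an added aromatic ring, not with a change in those counts. From the compounds shown here alone, how a carboxylic acid or an amine at this position would read remains open. Nothing available gives a reason for the step.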